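A Furan in Place of a Thiophene: What to Expect

The source may hold more compounds than are shown below. What is called first, only, known or untested is meant among the compounds shown, and "the series" means these compounds.

Compound 2 `Oc1ccccc1-c1cc(-c2ccsc2)cc(-c2ccccc2O)n1` stands in an assay on isolated protein for inhibition of DNA topoisomerase 1 (Homo sapiens), with a stated time of 30 min, tested at 20 uM (on this read-out higher numbers stand for a stronger effect at the one concentration tested and lower numbers for a weaker effect), with "not determined" (no result reported): no result was reported for it, and compound 3 `Oc1ccc(-c2cc(-c3ccsc3)cc(-c3ccccc3O)n2)cc1` likewise shows "not determined" (no result reported) in this assay. The only measured figure in this small set belongs to compound 1 `Oc1ccccc1-c1cc(-c2cccs2)cc(-c2ccccc2O)n1`, which in this assay gives 0.2%. Compound 4 `Oc1ccccc1-c1cc(-c2ccco2)cc(-c2ccccc2O)n1` is the untested member, and the change from compound 2 to compound 4 is furan-2-yl in place of thiophen-3-yl on an aromatic carbon. Among the compounds with values here, with no measured step between any two compounds here, and the one recorded value close to nil, the expectation is a step of no size beyond the scatter in this assay. Compound 4 is therefore expected to give 3% in this assay, estimated to lie between 0% and 15%.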

Compound 4, a percentage reported as inhibition, at one concentration (the size of the read-out at that concentration, not a potency): 0.2%
Compound 4: the middle estimate sits 2.8 percentage points above what was measured, and the stated range covers the measured number.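

In this assay, furan-2-yl in place of thiophen-2-yl on the aromatic carbon opposite the ring nitrogen gives no change at the digits printed from compound 1 to compound 4 (within the scatter). Within the data shown here, this is the first readable step at this position, and it shows that exchanging one five-membered aromatic ring for the other leaves the read-out where it was; the step to compound 4 from compound 2 cannot be read. No measurement given here offers an explanation for this result.

As far as these compounds go, whether any group at this position can lift the read-out remains open. An amine, a carboxylic acid or a longer chain here would test that.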